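Aryl urea series: a methoxy variant awaits its number

This account rests on a few compounds, and the source may have more. Where it says the series, first, only, none or still open, it means among the compounds named here.

Measured compounds:
Compound 1 `Cc1ccc(NC(=O)Nc2cccc(CNc3nccnc3Cl)c2)cc1` — 11500 nM
Compound 2 `O=C(Nc1cccc(CNc2nccnc2Cl)c1)Nc1ccc(Cl)cc1Br` — 6720 nM
Compound 3 `Cc1cccc(NC(=O)Nc2cccc(CNc3nccnc3Cl)c2)c1` — 11200 nM

In a functional assay on HepG2 cells (Homo sapiens) for antiproliferative activity, read by MTT assay, with a stated time of 48 h (on this read-out higher numbers stand for weaker inhibition and lower numbers for stronger inhibition), the three compounds sit close together. Compound 3 gives 11200 nM, and the steps to both of its neighbours stay inside the scatter: a 1.0-fold lower number from compound 1 to compound 3 (0.01 log units; within the scatter) and a 1.7-fold higher number from compound 2 to compound 3 (0.22 log units; within the scatter). Compound 3 therefore cannot be told apart from compound 1 or compound 2 on these numbers.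

Compound 4 `COc1ccc(NC(=O)Nc2cccc(CNc3nccnc3Cl)c2)cc1` is not yet measured. It differs from compound 3 in one place: 4-methoxyphenyl in place of 3-methylphenyl on an amide-type nitrogen.

Among the measured compounds shown here, no measured step swaps a methyl group for a methoxy group, so the bearing evidence is indirect. Moving the methyl group around the ring changed nothing, a 1.0-fold lower number from compound 1 to compound 3 (0.01 log units; within the scatter), and a much larger exchange of the aryl group gave only a 1.7-fold lower number from compound 1 to compound 2 (0.23 log units; within the scatter), also within the scatter. Every change tried on this amide-type nitrogen has left this assay essentially flat. Compound 4 is therefore expected to land where the others do, with the step from compound 3 estimated as a 1.1-fold lower number from compound 3 to compound 4 (0.05 log units; within the scatter), that is, no step beyond the scatter in either direction. The estimate for compound 4 is 10000 nM, with a likely range from 4500 nM to 22000 nM.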

Compound 4, half-maximal inhibitory concentration: 12000 nM
Estimate against measurement, compound 4: 1.2-fold (0.08 log units) below, within the range that was stated.
By their numbers in this assay, from the lowest: compounds 2, 3, 1 and 4 (each within the scatter of the next).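

In this assay, among the compounds shown here, this position on the amide-type nitrogen now has a direct exchange of methoxy in place of methyl on an aromatic carbon, which the earlier compounds lacked, and the result is a 1.0-fold higher number from compound 1 to compound 4 (0.02 log units; within the scatter). The 4-methoxyphenyl group also adds an oxygen and a hydrogen-bond acceptor to the aryl groups tried here, yet the comparison with 3-methylphenyl gives a 1.1-fold higher number from compound 3 to compound 4 (0.03 log units; within the scatter), and the comparison with 2-bromo-4-chlorophenyl gives a 1.8-fold higher number from compound 2 to compound 4 (0.25 log units; within the scatter), so all four aryl groups remain inseparable on this read-out. The compounds offer no independent measurement that could explain this flat behaviour.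

The compounds shown leave open whether an amine or a carboxylic acid on this aryl ring, or a longer chain in place of the ring, would move the number beyond the scatter. They also leave open whether this insensitivity would hold if the rest of the shared core were changed, since all four compounds carry that core unchanged.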